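Positional swap of carboxy and chloro on the aryl ether

The compounds below may be only part of what the source reports. "The series", "measured", "known", "first", "only" and "open" are said of these compounds alone.

Measured so far in an assay for positive allosteric modulation of metabotropic glutamate receptor 2 (Rattus norvegicus); a lower number here means that less compound is needed, a higher number that more compound is needed for the effect:
compound 1 `Cc1c(OC[C@H](C)Oc2ccc(F)c(C(=O)O)c2)ccc(C(=O)CC(C)(C)C)c1O` gives 142 nM
compound 2 `Cc1c(O[C@H](C)COc2ccc(F)c(C(=O)O)c2)ccc(C(=O)CC(C)(C)C)c1O` gives 83 nM
compound 3 `Cc1c(OC[C@@H](C)COc2ccc(Cl)c(C(=O)O)c2)ccc(C(=O)CC(C)(C)C)c1O` gives 377 nM

Compound 3 stands at the highest number of the three in this assay; compound 1 is closest to it and compound 2 furthest, and both of those gaps are beyond the scatter, so compound 3 needs more material for the effect than either. Within the data shown here, compound 1 and compound 2 differ from compound 3 in several places at once, so no single step between measured compounds is on hand.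

Compound 4 `Cc1c(OC[C@@H](C)COc2ccc(C(=O)O)c(Cl)c2)ccc(C(=O)CC(C)(C)C)c1O` is the unmeasured partner of compound 3. The two have the same atoms, joined differently: 4-carboxy-3-chlorophenyl in place of 3-carboxy-4-chlorophenyl on an oxygen on a saturated carbon. The carboxylic acid and the chlorine trade places on the ring; the rest of the molecule, including the shared core and the three-carbon linker, stays as it is.

Among the measured compounds shown here, no measured pair speaks to this swap, so the expectation rests on compound 3 alone. Since the acid is the only hydrogen-bond donor on that side, moving it seems more likely to cost than to gain, and a step of a 1.6-fold higher number from compound 3 to compound 4 (0.20 log units; within the scatter) is expected, modest and towards a higher number. For compound 4 the estimated value is 600 nM, with a range from 180 nM to 2000 nM.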

Compound 4, half-maximal effective concentration: 50 nM
For compound 4 the middle estimate is 12-fold (1.08 log units) above the measured one, and the stated range ends above it.
By their numbers in this assay, from the lowest: compounds 4, 2 and 1 (each within the scatter of the next, the first and the last beyond it); then compound 3.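

In this assay, among these compounds, the exchange of 3-carboxy-4-chlorophenyl for 4-carboxy-3-chlorophenyl on an oxygen on a saturated carbon gives a 7.5-fold lower number from compound 3 to compound 4 (0.88 log units; beyond the scatter) with the shared core and linker untouched, the first single-change comparison. The two groups have the same atoms and the same counts of donors and acceptors, so the arrangement of the carboxylic acid and the chlorine on the ring alone separates the two numbers, and this position is clearly sensitive to that arrangement. No measurement on hand accounts for the step.

Going by these compounds, this reading rests on one pair, so it remains open whether the same exchange of places would carry over to the fluorine-bearing compound 1 and compound 2, or to other linkers. Also open, on these data alone, is how this position would respond if the carboxylic acid of the 4-carboxy-3-chlorophenyl group gave way to a tetrazole or a primary amide, or if the chlorine gave way to a methyl or a methoxy group.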